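From phenyl to 1H-imidazol-1-yl: how much stays bound?

The source may report more compounds than this note shows. Statements on the series, on what has been measured and on what is new or still open speak of the compounds shown alone.

Results so far in an ADME assay on the whole organism (serum) for protein binding, with Homo sapiens as the target, using equilibrium dialysis, are:
- compound 1 `Cc1ccn(-c2ccc(Cn3cc(C(=O)O)c(=O)c4cccnc43)cc2)n1` gives 98.8%
- compound 2 `O=C(O)c1cn(Cc2ccc(-c3ccccc3)cc2)c2ccsc2c1=O` gives 98.7%

Compound 2 stands level with compound 1: the two values lie within the scatter, and in both very little compound is left free. Compound 3 `O=C(O)c1cn(Cc2ccc(-n3ccnc3)cc2)c2ccsc2c1=O` keeps the rest of compound 2 but carries 1H-imidazol-1-yl in place of phenyl on an aromatic carbon, para to a large group 1H-imidazol-1-yl in place of phenyl on an aromatic carbon in the structure. Among the compounds with values here, no measured pair yet shows what such a change does in this assay so the expectation rests on the structures alone. A modest shift toward more free compound is expected, slightly beyond the scatter. The estimated size of this shift is a 2.7-fold higher unbound fraction from compound 2 to compound 3 (0.43 log units; beyond the scatter) in the free share. For compound 3 the estimated value is 96.5% with an expected range from 91% to 98.8% in this measurement.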

Compound 3, plasma protein binding: 80.1%
Estimate against measurement, compound 3: 5.7-fold (0.75 log units) (unbound fraction) below, outside the stated range (below it).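

In this assay, 1H-imidazol-1-yl in place of phenyl on this aromatic carbon, para to a large group, gives a 15-fold higher unbound fraction from compound 2 to compound 3 (1.18 log units; beyond the scatter) and so moves a compound out of the near-fully bound range. This shows that a single change at this position can alter the free share greatly, a reading that compound 1 and compound 2, which differ in more than one place, could not give. Nothing available here accounts for the size of this step.

Which feature of the entering ring matters remains open, and a pyridine ring or a morpholine on the same carbon would help to separate the possibilities. Also open, from the compounds shown here alone, is whether the same change would have a similar effect on another core, such as that of compound 1.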